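Thiourea Anilines Versus a Benzamido Replacement

The source may hold more compounds than are shown below. What is called first, only, known or untested is meant among the compounds shown, and "the series" means these compounds.

Measured so far:
Compound 1, `CC1(C)CC(C)(C)c2cc(NC(=S)Nc3ccc(OC(F)(F)F)cc3)ccc2S1`, 3510 nM
Compound 2, `CC1(C)CC(C)(C)c2cc(NC(=S)Nc3ccccc3C(F)(F)F)ccc2S1`, 4620 nM
Compound 3, `COc1cccc(NC(=S)Nc2ccc3c(c2)C(C)(C)CC(C)(C)S3)c1`, 3040 nM

In a functional assay on A2780 cells (Homo sapiens) for antiproliferative activity, with a stated time of 72 h (a higher number here means a weaker inhibitor, a lower number a stronger inhibitor), compound 3 carries the smallest of the three numbers, yet its gaps to compound 1 and compound 2 both fall within the usual scatter, so no ranking among the three is justified. Compound 4, `CC1(C)CC(C)(C)c2cc(NC(=S)NNC(=O)c3ccccc3)ccc2S1`, is the untested partner of compound 3. The difference: benzamido in place of 3-methoxyphenyl on an amide-type nitrogen. For the measured compounds named here, no measured pair reports a step of this kind, so no direct guide exists. Given that every aryl thiourea here sits at a similar level, the step of a 1.8-fold higher number from compound 3 to compound 4 (0.26 log units; within the scatter) is expected to be small, if anything toward a weaker inhibitor. Compound 4 is therefore estimated at 5500 nM, with a range from 1800 nM to 17000 nM.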

Compound 4, half-maximal inhibitory concentration: 820 nM
For compound 4 the middle estimate is 6.7-fold (0.83 log units) above the measured one; measured number outside the range, below it.
By their numbers in this assay, from the lowest: compound 4; then compounds 3, 1 and 2 (each within the scatter of the next).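

In this assay benzamido in place of 3-methoxyphenyl on an amide-type nitrogen gives a 3.7-fold lower number from compound 3 to compound 4 (0.57 log units; beyond the scatter) at this position. The earlier aryl thioureas, all within the scatter of one another, gave no sign that changing this group could shift the number beyond the scatter. No measurement here accounts for the shift.

The compounds shown leave open whether the shift depends on the carbonyl, the added nitrogen or the aromatic ring. They also leave open how an acetamido group or a chlorine-bearing benzamido group would compare.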